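Adding a Second Fluorine to a Benzyl Group

The source may hold more compounds than are shown below. What is called first, only, known or untested is meant among the compounds shown, and "the series" means these compounds.

This study concerns a small set of compounds built on one shared core and tested in an ADME assay on HOS cells (Homo sapiens) for cytotoxicity; a lower number here means a stronger inhibitor, a higher number a weaker inhibitor. Compound 1 `O=C1c2c(ccc(O)c2O)CN1Cc1ccccc1` carries a plain benzyl group; in this assay compound 1 gives "not determined" (no result reported), so no result is available for it. Compound 2 `O=C1c2c(ccc(O)c2O)CN1Cc1cccc(F)c1` carries one fluoro group on that benzyl ring, and in this assay compound 2 gives 8600 nM. That is the only number shown, so compound 2 stands alone as the single point of reference. Compound 3 `O=C1c2c(ccc(O)c2O)CN1Cc1cc(F)cc(F)c1` has not yet been tested; it differs from compound 2 by fluoro in place of hydrogen on an aromatic carbon. Among the compounds with values here, no step between two measured compounds is available to guide the expectation, and the change is limited to one added fluoro group, so a step no larger than the usual scatter is expected, in either direction. For compound 3 a value of about 8000 nM is therefore estimated, within a range from 3000 nM to 20000 nM, which amounts to an expected step of a 1.1-fold lower number from compound 2 to compound 3 (0.03 log units; within the scatter).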

Compound 3, half-maximal inhibitory concentration: 17200 nM
Estimate against measurement, compound 3: 2.2-fold (0.33 log units) below, and the stated range covers the measured number.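

In this assay, the second fluoro group, which sits meta to the first fluoro group and meta to a large group on the aromatic ring, gives a 2.0-fold higher number from compound 2 to compound 3 (0.30 log units; within the scatter). Within the data shown here, this is the first step that can be read in this set, and it shows that swapping hydrogen for fluoro at this place produces no difference that can be separated from the ordinary spread of repeated measurements. Nothing shown here bears on what lies behind this result.

The compounds shown carry only hydrogen or fluoro at this place, so it remains open whether a group with more atoms, such as methoxy, trifluoromethyl or an amine, would leave the number just as undisturbed. Also open, going by these compounds, is whether a carboxylic acid there would give a step beyond the scatter.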